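The compounds below may be only part of what the source reports. "The series", "measured", "known", "first", "only" and "open" are said of these compounds alone.

Working notes on the series. Within the data shown here, compound 1 `CCCSc1nc(N/N=C/c2ccc(Cl)cc2)c2nnn(Cc3ccccc3)c2n1` and compound 2 `CCCSc1nc(N/N=C(\C)c2ccccc2O)c2nnn(Cc3cccc(Cl)c3)c2n1` are the two measured members; compound 3 `CCCSc1nc(N/N=C/c2ccc(Br)cc2)c2nnn(Cc3ccccc3)c2n1` is not yet measured. In a functional assay on MCF7 cells (Homo sapiens) for antiproliferative activity, read by MTT assay, with a stated time of 72 h (a higher number here means a weaker inhibitor, a lower number a stronger inhibitor), compound 1 gives only a limit, > 64000 nM, and no number. In this assay compound 2 gives 39900 nM. Compound 1 therefore stands at the limit of > 64000 nM in this assay, at which 1 of the 2 values shown sits, and its position relative to compound 2 cannot be fixed from these data. Among the measured compounds shown here, no step between two measured compounds that differ in one place is available. The change from compound 1 to compound 3 is bromo in place of chloro on an aromatic carbon. With a halogen for a halogen at the same place, the expected step in this assay is none beyond the usual scatter: a step that the limit leaves unreadable from compound 1 to compound 3. Compound 3 is expected to sit near the same limit, estimated at 70000 nM, within 30000 nM to 160000 nM, with a substantial chance that the assay again reports only a limit.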

Compound 3, half-maximal inhibitory concentration: > 64000 nM
Compound 3 gave a limit, no number (the forecaster's own chance of this, stated with the estimate: 60%); the middle value lies beyond the limit too.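

Compound 1 and compound 3 both give only limits in this assay, so no step can be read between them: the limit of > 64000 nM in this assay, at which 2 of the 3 values shown sit.

The compounds shown leave open the actual values of both compounds and whether 4-chlorophenyl and 4-bromophenyl differ at all in this assay.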